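The source may hold more compounds than are shown below. What is called first, only, known or untested is meant among the compounds shown, and "the series" means these compounds.

Three compounds share one core, and on a functional assay on SV5A8 cells (Homo sapiens) for cytotoxicity (on this read-out higher numbers stand for weaker inhibition and lower numbers for stronger inhibition), every one of them stops at a limit. Compound 1 `Cc1ccc2c(NCc3ccc(NC(=O)C4CCN(Cc5ccc(F)cc5)CC4)cc3)nc(N(C)C)nc2c1` gives only a limit, > 4820 nM. Compound 2 `Cc1ccc2c(NCc3ccc(NC(=O)C4CCN(CC(C)C)CC4)cc3)nc(N(C)C)nc2c1` likewise gives only a limit, > 10500 nM. Compound 3 `Cc1ccc2c(NCc3ccc(NC(=O)C4CCN(CC5CCNCC5)CC4)cc3)nc(N(C)C)nc2c1` also gives only a limit, > 8070 nM. Compound 3 thus has no fixed place among the numbers shown, since its value and the other two are limits. The steps a step that the two limits leave unreadable from compound 1 to compound 2, a step that the two limits leave unreadable from compound 1 to compound 3 and a step that the two limits leave unreadable from compound 2 to compound 3 are all unreadable. Compound 4 `Cc1ccc2c(NCc3ccc(NC(=O)C4CCN(C)CC4)cc3)nc(N(C)C)nc2c1` differs from compound 3 by hydrogen in place of piperidin-4-yl on a saturated chain carbon bound to an amine nitrogen in a ring. Among the compounds with values here, none of the measured steps gives a readable size for such a change, so no direction follows from them. Compound 4 is expected to show a step that the limit leaves unreadable from compound 3 to compound 4, a step not expected to exceed the scatter. Compound 4 is estimated at 10000 nM, within 4000 nM to 30000 nM, and this assay is expected most likely to report only a limit again.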

Compound 4, half-maximal inhibitory concentration: > 17300 nM
Compound 4 ended at the assay's limit; the forecaster's own chance of this, stated with the estimate: 80%; middle value at least 1.7-fold (0.23 log units) from the limit.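

In this assay, within the data shown here, compound 4 gives only a limit, as do compound 1, compound 2 and compound 3, so no step among them can be read. The compounds shown leave open whether changing this group shifts cytotoxicity at all.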